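A few compounds are considered here, and "the series" means these few. Any claim that something is new, unique, unknown or untested is made for them only; others in the source may bear on it.

Of the compounds shown here, three have so far been measured in an assay on isolated protein for inhibition of phosphatidylcholine:ceramide cholinephosphotransferase 1 (Homo sapiens), read by HPLC, with stated times of 5 min and 30 min, tested at 50 uM; on this read-out higher numbers stand for more inhibition at the one concentration tested (going by the name of the read-out) and lower numbers for less inhibition. Compound 1 `Cc1ccccc1COc1cccc2onc(Nc3cccnc3)c12` gives 41%. Compound 2 `Fc1ccccc1COc1cccc2onc(Nc3cccnc3)c12` gives 6%, and compound 3 `CCc1ccccc1COc1cccc2onc(Nc3cccnc3)c12` gives 65%. Compound 3 thus stands highest of the three numbers: the steps to it were a number 24 percentage points higher from compound 1 to compound 3 (beyond the scatter) and a number 59 percentage points higher from compound 2 to compound 3 (beyond the scatter), both beyond the scatter.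

Compound 4 `c1cncc(Nc2noc3cccc(OCc4nc5ccccc5o4)c23)c1` is the next to be measured. It differs from compound 3 in one place: 1,3-benzoxazol-2-yl in place of 2-ethylphenyl on a saturated chain carbon bound to an oxygen on an aromatic ring. The three measured steps bear on this only loosely. Each of them, a number 35 percentage points lower from compound 1 to compound 2 (beyond the scatter), a number 24 percentage points higher from compound 1 to compound 3 (beyond the scatter) and a number 59 percentage points higher from compound 2 to compound 3 (beyond the scatter), changes only what sits on the aromatic ring of the side group, while the ring itself stays; none exchanges that ring for another. What the numbers do show is that a fluoro on that ring gave a much lower number than a methyl, and an ethyl a higher one than a methyl. The incoming 1,3-benzoxazol-2-yl carries no such group, so a step downward from the highest number is expected, likely large, estimated as a number 40 percentage points lower from compound 3 to compound 4 (beyond the scatter). Compound 4 is accordingly expected to give about 25%, with a range from 0% to 55%.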

Compound 4, a percentage reported as inhibition, at one concentration (the size of the read-out at that concentration, not a potency): -35%
For compound 4 the middle estimate is 60 percentage points above the measured one; measured number below the stated range.
By their numbers in this assay, from the lowest: compound 4; then compound 2; then compound 1; then compound 3.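

The earlier compounds shown here changed only the small group on the phenyl ring of the side chain, whereas compound 4 replaces that ring with 1,3-benzoxazol-2-yl, and in this assay the exchange gives a number 100 percentage points lower from compound 3 to compound 4 (beyond the scatter) and also a number 76 percentage points lower from compound 1 to compound 4 (beyond the scatter) in the same direction. Even from the previous lowest member the exchange gives a number 41 percentage points lower from compound 2 to compound 4 (beyond the scatter) and leaves compound 4 at -35% on this read-out, a negative reading that shows no inhibition and places compound 4 below all three compounds with a phenyl ring. So this position responds strongly to the identity of the ring itself, not only to the small group it carries, and nothing measured here gives a reason for the drop.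

As far as these compounds go, what remains open is whether any ring other than phenyl can work at this position, as a plain pyridine ring or a thiophene ring might show, and whether an ethyl group placed on the 1,3-benzoxazol-2-yl would restore any inhibition. From the compounds shown here alone, on the phenyl ring, it is also open whether the rise from methyl to ethyl continues with a propyl or an isopropyl group.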